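A few compounds are considered here, and "the series" means these few. Any claim that something is new, unique, unknown or untested is made for them only; others in the source may bear on it.

Values in a functional assay on DU-145 cells (Homo sapiens) for inhibition, read by trypan blue exclusion, with a stated time of 96 h; a higher number here means a weaker inhibitor of growth, a lower number a stronger inhibitor of growth:
- compound 1 `O=C(O)c1ccc(C(=O)/C(=C\c2ccc(Cl)c([N+](=O)[O-])c2)SCc2ccc(Cl)cc2)cc1`: 1000 nM
- compound 2 `O=C(O)c1ccc(C(=O)/C(=C\c2ccc(Cl)c([N+](=O)[O-])c2)SCc2ccc(Br)cc2)cc1`: 500 nM
- compound 3 `O=C(O)c1ccc(C(=O)/C(=C\c2ccc(Cl)c([N+](=O)[O-])c2)SCc2ccccc2F)cc1`: 1000 nM

Not yet measured: compound 4 `COc1ccc(/C=C(/SCc2ccc(Cl)cc2)C(=O)c2ccc(C(=O)O)cc2)cc1`.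

Compound 1 stands level with compound 3, and the gap on the other side is a 2.0-fold lower number from compound 1 to compound 2 (0.30 log units; within the scatter). The change to compound 4 is 4-methoxyphenyl in place of 4-chloro-3-nitrophenyl on a double-bonded chain carbon bound to a double-bonded chain carbon. Among the compounds with values here, no measured step touches this place. Both a 2.0-fold lower number from compound 1 to compound 2 (0.30 log units; within the scatter) and no change at the digits printed from compound 1 to compound 3 (within the scatter) concern the group on the saturated chain carbon bound to a sulfur, so they give no size or direction for this change. A cautious judgement, not shown by the data, gives an expected step in this assay of a 2.0-fold higher number from compound 1 to compound 4 (0.30 log units; within the scatter). For compound 4 the estimated value is 2000 nM, with an expected range of 500 nM to 10000 nM.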

Compound 4, concentration for 50% growth inhibition: 10000 nM
Compound 4: middle estimate off by 5.0-fold (0.70 log units), on the low side; the range from low to high includes it.
By their numbers in this assay, from the lowest: compounds 2, 1 and 3 (each within the scatter of the next); then compound 4.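

In this assay, within the data shown here, the group on the double-bonded chain carbon bound to a double-bonded chain carbon matters more than the earlier steps could show: 4-methoxyphenyl in place of 4-chloro-3-nitrophenyl gives a 10-fold higher number from compound 1 to compound 4 (1.00 log units; beyond the scatter). All the steps on the saturated chain carbon bound to a sulfur stay within the scatter, so this is the only change shown that moves the number beyond it. No available evidence accounts for this step.

The change swaps the whole aryl group, so the separate contributions of the chloro, nitro and methoxy groups remain unresolved. On these data alone, how an amine or a nitrile on this ring would read is also open.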